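A few compounds are considered here, and "the series" means these few. Any claim that something is new, unique, unknown or untested is made for them only; others in the source may bear on it.

Working notes on the series. Compound 1 `CCN(CC)c1cc2[nH]c(C3CCCCC3)nc2cc1NC(=O)c1cnccn1` carries a pyrazin-2-yl amide on the shared core. In an ADME assay on Vero cells (Chlorocebus sabaeus) for cytotoxicity, read by resazurin assay, with a stated time of 3 days (on this read-out lower numbers stand for stronger inhibition and higher numbers for weaker inhibition), compound 1 gives > 100 ug/mL, which is a limit of the assay and not a number. Compound 2 `CCCCOC(=O)Nc1cc2nc(C3CCCCC3)[nH]c2cc1N(C)C` is the second measured member. In this assay compound 2 also gives > 100 ug/mL, again a limit rather than a number. Within the data shown here, both values thus sit at the limit of > 100 ug/mL in this assay, at which 2 of the 2 values shown sit, so no step between measured compounds can be sized and compound 1 stands only at that limit. Compound 3 `CCN(CC)c1cc2[nH]c(C3CCCCC3)nc2cc1NC(=O)c1ccc(OC(F)F)cc1` has not yet been measured. It differs from compound 1 by 4-(difluoromethoxy)phenyl in place of pyrazin-2-yl on a carbonyl carbon. Among the measured compounds shown here, with no measured step on this core, the expectation for compound 3 is of no change beyond the scatter, a step that the limit leaves unreadable from compound 1 to compound 3, most likely again a limit. Compound 3 is accordingly estimated at 120 ug/mL, within 50 ug/mL to 250 ug/mL.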

Compound 3, half-maximal inhibitory concentration: > 100 ug/mL
Compound 3: a limit, no number (the forecaster's own chance of this, stated with the estimate: 75%); the middle value does not contradict the limit.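

In this assay compound 3 gives > 100 ug/mL, again a limit and not a number. Among these compounds, no step from compound 1 to compound 3 can be read: the limit of > 100 ug/mL in this assay, at which 3 of the 3 values shown sit. The compounds shown leave open whether any change on the shared core gives a readable number in this assay.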